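Piperidine amide variation in a diaryl thioether series

A few compounds are considered here, and "the series" means these few. Any claim that something is new, unique, unknown or untested is made for them only; others in the source may bear on it.

Measured compounds:
compound 1 `Fc1ccc(C(SCCNC2CCN(Cc3ccc(C(F)(F)F)cc3)CC2)c2ccc(F)cc2)cc1`: 186 nM
compound 2 `O=C(c1ccc(F)cc1)N1CCC(NCCSC(c2ccc(F)cc2)c2ccc(F)cc2)CC1`: 32.1 nM
compound 3 `CC(C)(C)C(=O)N1CCC(NCCSC(c2ccc(F)cc2)c2ccc(F)cc2)CC1`: 163 nM

In an assay on membranes from Cortex for displacement of a labelled ligand from Sigma non-opioid intracellular receptor 1 (Cavia porcellus), read by scintillation counting, with a stated time of 120 min (on this read-out higher numbers stand for weaker inhibition and lower numbers for stronger inhibition), compound 3 gives 163 nM, the second highest of the three numbers. Its nearest neighbour is compound 1, a 1.1-fold lower number from compound 1 to compound 3 (0.06 log units; within the scatter), so the two are not separated. The furthest is compound 2, a 5.1-fold higher number from compound 2 to compound 3 (0.71 log units; beyond the scatter), a modest gap beyond the scatter.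

Compound 4 `O=C(C1CC1)N1CCC(NCCSC(c2ccc(F)cc2)c2ccc(F)cc2)CC1` follows from compound 3 by cyclopropyl in place of tert-butyl on a carbonyl carbon. Within the data shown here, the only measured step at the same position is a 5.1-fold higher number from compound 2 to compound 3 (0.71 log units; beyond the scatter), where an aromatic group on the carbonyl carbon gave the lower number and tert-butyl the higher. Among the measured compounds shown here, no step compares two non-aromatic groups on that carbon, so the effect of exchanging one small carbon substituent for another is not read directly from the data. The replacement at the ring nitrogen itself, a 1.1-fold lower number from compound 1 to compound 3 (0.06 log units; within the scatter), was within the scatter.

On this basis little movement is expected for compound 4 in this assay, a 1.1-fold lower number from compound 3 to compound 4 (0.04 log units; within the scatter), with the range allowing a modest shift either way. Compound 4 is estimated at 150 nM, within 60 nM to 400 nM.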

Compound 4, inhibition constant: 46.4 nM
Estimate against measurement, compound 4: 3.2-fold (0.51 log units) above; the measured number lies below the stated range.
By their numbers in this assay, from the lowest: compounds 2 and 4 (each within the scatter of the next); then compounds 3 and 1 (each within the scatter of the next).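

At the carbonyl carbon, this assay now gives a step between two non-aromatic groups, a 3.5-fold lower number from compound 3 to compound 4 (0.55 log units; beyond the scatter), so the higher number seen with tert-butyl does not extend to every non-aromatic group, and a 1.4-fold higher number from compound 2 to compound 4 (0.16 log units; within the scatter) leaves cyclopropyl and 4-fluorophenyl unseparated. Replacing 4-(trifluoromethyl)benzyl on the ring nitrogen with an acyl group therefore does not give one outcome: (tert-butyl)carbonyl stays within the scatter of the benzyl compound, whereas cyclopropylcarbonyl gives a 4.0-fold lower number from compound 1 to compound 4 (0.60 log units; beyond the scatter). No available evidence bears on the separation of tert-butyl from cyclopropyl at this position.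

Among these compounds, with only three groups on the carbonyl carbon, the series does not show whether the three-membered ring itself matters or whether other small carbon groups would behave alike, and methyl, isopropyl and cyclobutyl on that carbon would test this. Also open, on these data alone, is whether a carbonyl carbon bearing a group with an amine or a carboxylic acid would stay with cyclopropyl and 4-fluorophenyl or move towards tert-butyl on this read-out.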